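A few compounds are considered here, and "the series" means these few. Any claim that something is new, unique, unknown or untested is made for them only; others in the source may bear on it.

Measured so far in a functional assay on MDA-MB-231 cells (Homo sapiens) for antiproliferative activity, read by MTT assay, with a stated time of 72 h; on this read-out lower numbers stand for stronger inhibition and higher numbers for weaker inhibition:
- compound 1 `COc1cc(-c2nccn2C)cc(OC)c1OC`: > 100000 nM, a limit of the assay and not a number
- compound 2 `CCCCn1ccnc1-c1cc(OC)c(OC)c(OC)c1`: 70400 nM
- compound 3 `COc1cc(-c2nccn2-c2ccc3[nH]ccc3c2)cc(OC)c1OC`: 4300 nM

Of the two results that are true numbers in this assay, compound 2 has the higher, at 70400 nM. The nearest result is lower, and the gap to it lies beyond the scatter. Here compound 3 gives 4300 nM. Compound 1 stands at a limit, (the limit of > 100000 nM in this assay, at which 1 of the 3 values shown sits). For the measured compounds named here, the only measured single-place step, an at least 1.4-fold lower number from compound 1 to compound 2 (0.15 log units; that floor lies within the scatter), starts from that limit and offers little guidance on size.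

The next compound is compound 4 `COc1cc(-c2nccn2-c2cccc(C)c2)cc(OC)c1OC`, which differs from compound 2 in one place: 3-methylphenyl in place of butyl on an aromatic nitrogen. Here 3-methylphenyl stands in place of butyl on an aromatic nitrogen. Going by the values given here, no measured step covers this exact exchange. The closest guide is compound 3, which also carries an aromatic group on that nitrogen and gives 4300 nM. A move to a lower number in this assay is therefore expected, probably not quite as far as compound 3, and the support for it is thin. The expected size is a 5.9-fold lower number from compound 2 to compound 4 (0.77 log units; beyond the scatter), beyond the scatter. For compound 4 the estimated value is 12000 nM, with an expected range of 3000 nM to 50000 nM.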

Compound 4, half-maximal inhibitory concentration: 11700 nM
Compound 4: middle estimate off by 1.0-fold (0.01 log units), on the high side, and the stated range covers the measured number.
By their numbers in this assay, from the lowest: compound 3; then compound 4; then compound 2. At a limit, above all of these: compound 1.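

In this assay, for the compounds shown here, 3-methylphenyl in place of butyl on the aromatic nitrogen gives a 6.0-fold lower number from compound 2 to compound 4 (0.78 log units; beyond the scatter), the first step at this position between two true numbers that lies beyond the scatter. The entering group is one six-membered aromatic ring of carbon only, with 0 hydrogen-bond donors, so a lower number at this position does not depend on a ring nitrogen or a donor in the group. With methyl as the starting group, the exchange gives an at least 8.5-fold lower number from compound 1 to compound 4 (0.93 log units; beyond the scatter), and this is only a floor, compound 1 being at a limit and not a number: the limit of > 100000 nM in this assay, at which 1 of the 4 values shown sits.

The compounds shown leave open whether the lower number goes with the aromatic ring or simply with a larger group, and a plain phenyl or a cyclohexyl on that nitrogen would help separate the two. Also open, from the compounds shown here alone, is what the methyl on the ring contributes and how far other ring substituents, such as an amine or a methoxy, would bring compound 4, at 11700 nM, towards compound 3, at 4300 nM.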